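A few compounds are considered here, and "the series" means these few. Any claim that something is new, unique, unknown or untested is made for them only; others in the source may bear on it.

Of the compounds shown here, three have so far been tested in a functional assay on T47D cells (Homo sapiens) for cytotoxicity, read by colorimetric assay and MTT assay; a lower number here means a stronger inhibitor, a higher number a weaker inhibitor. Compound 1 `COc1ccc2cc(-c3ccccc3)c(O)nc2c1` gives 10000 nM, and compound 2 `COc1cc(OC)c2cc(-c3ccccc3)c(O)nc2c1` gives 10000 nM. These two differ by a methoxy in place of hydrogen on an aromatic carbon, and the size of that step is no change at the digits printed from compound 1 to compound 2 (within the scatter). Compound 3 `COc1ccc(-c2cc3c(OC)cc(OC)cc3n(CC(=O)OCc3ccccc3)c2=O)cc1` gives 10000 nM, level with both of the others.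

Compound 4 `COc1ccc(-c2cc3c(OC)cc(OC)cc3n(CCC(=O)OCc3ccccc3)c2=O)cc1` differs from compound 3 in one place: (benzyloxycarbonyl)methyl in place of benzyloxycarbonyl on a saturated chain carbon bound to an aromatic nitrogen. In other words, (benzyloxycarbonyl)methyl stands in place of benzyloxycarbonyl on a saturated chain carbon bound to an aromatic nitrogen. Within the data shown here, no measured step tests this change directly, since the only step available concerns a different group in a different place. It therefore offers only weak guidance, and what it shows is no movement in this assay. No shift beyond the scatter is expected, so the expected step is no change at the digits printed from compound 3 to compound 4 (within the scatter). For compound 4 the estimated value is 10000 nM, with an expected range from 3000 nM to 12000 nM.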

Compound 4, half-maximal inhibitory concentration: 10000 nM
Compound 4: the middle estimate sits on the measured number at the digits printed, and the stated range covers the measured number.
By their numbers in this assay, from the lowest: compounds 1, 2, 3 and 4 (each within the scatter of the next).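

In this assay, the swap of benzyloxycarbonyl for (benzyloxycarbonyl)methyl on a saturated chain carbon bound to an aromatic nitrogen adds a single carbon and gives no change at the digits printed from compound 3 to compound 4 (within the scatter) in this comparison. This is the first step shown at this position, as the only earlier step concerned a methoxy on an aromatic carbon, and it shows that this small extension leaves the number where it was. No supporting data are available to explain this result.

As far as these compounds go, with compound 3 and compound 4 both carrying the benzyloxycarbonyl ending, the effect of a different ending at this position remains open, such as a free carboxylic acid, an amide or an amine. From the compounds shown here alone, a longer chain also remains untested here, and so does any change at this position that would bring the number away from the level shared by all four compounds.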